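Turning Over Two Stereocentres of Compound 3

The source may hold more compounds than are shown below. What is called first, only, known or untested is meant among the compounds shown, and "the series" means these compounds.

Compound 1 `CCCCC[C@@H](C[C@@H](O)C[C@H]1CC=CC(=O)O1)OC`: 25200 nM
Compound 2 `CCCCC[C@H](C[C@@H](O)C[C@@H]1CC=CC(=O)O1)OC`: 91500 nM
Compound 3 `CCCCC[C@H](C[C@H](O)C[C@@H]1CC=CC(=O)O1)OC`: 30000 nM

These three compounds were tested in a functional assay on A2780 ADR cells (Homo sapiens) for cytotoxicity, read by MTT assay, with a stated time of 24 h; a lower number here means a stronger inhibitor, a higher number a weaker inhibitor. They have the same atoms and bonds, and differ only in configuration as drawn. Compound 3 gives 30000 nM, which lies within the scatter of compound 1, while a 3.1-fold lower number from compound 2 to compound 3 (0.48 log units; beyond the scatter) separates it from compound 2.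

The next compound is compound 4 `CCCCC[C@@H](C[C@H](O)C[C@H]1CC=CC(=O)O1)OC`. The change is the two compounds have the same atoms and bonds and differ only in configuration as drawn: 2 of 3 stereo elements differ; a stereocentre at a saturated chain carbon is drawn R in compound 3 and S in compound 4; a stereocentre at a saturated ring carbon is drawn S in compound 3 and R in compound 4: a stereocentre at a saturated chain carbon is drawn R in compound 3 and S in compound 4, and a stereocentre at a saturated ring carbon is drawn S in compound 3 and R in compound 4.

The nearest guide is a 3.6-fold higher number from compound 1 to compound 2 (0.56 log units; beyond the scatter), which also changes one chain stereocentre and the ring stereocentre, though with the drawn letters running the opposite way. In contrast, a 1.2-fold higher number from compound 1 to compound 3 (0.08 log units; within the scatter) inverts all the stereocentres and stays within the scatter, so the direction is not secure. Three compounds are a thin basis, but a modest move towards a higher number, meaning a weaker inhibitor, seems most likely. The expected change is a 2.2-fold higher number from compound 3 to compound 4 (0.34 log units; beyond the scatter). For compound 4 the estimated value is 65000 nM, with an expected range from 25000 nM to 140000 nM.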

Compound 4, half-maximal inhibitory concentration: 48000 nM
The estimate for compound 4 lay 1.4-fold (0.13 log units) above the measured number; low and high end bracket the measured number.
By their numbers in this assay, from the lowest: compounds 1, 3, 4 and 2 (each within the scatter of the next, the first and the last beyond it).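

Compound 4 completes a second mirror-image pair, and a 1.9-fold lower number from compound 2 to compound 4 (0.28 log units; within the scatter) shows that inverting all the stereocentres stays within the scatter here too, as it did in a 1.2-fold higher number from compound 1 to compound 3 (0.08 log units; within the scatter). The swap of one chain stereocentre and the ring stereocentre, which looked like a real effect in a 3.6-fold higher number from compound 1 to compound 2 (0.56 log units; beyond the scatter), now stays within the scatter in a 1.6-fold higher number from compound 3 to compound 4 (0.20 log units; within the scatter), so this kind of change has no constant size across the set. Likewise, a change at a single chain stereocentre gives a 1.9-fold higher number from compound 1 to compound 4 (0.28 log units; within the scatter), within the scatter, whereas a 3.1-fold lower number from compound 2 to compound 3 (0.48 log units; beyond the scatter) lies beyond it.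

Compound 4 sits within the scatter of each of the other three compounds, so only compound 2 stands apart from compounds 1 and 3, and these numbers do not show which stereocentre, if any, accounts for that gap. Also open, as far as these compounds go, is how the numbers would respond to a different group on the same core, such as an amine in place of the hydroxyl or a longer chain in place of the present one.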